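From a Methyl to a 2-Fluorophenyl on the Ring Nitrogen

This account rests on a few compounds, and the source may have more. Where it says the series, first, only, none or still open, it means among the compounds named here.

Of the compounds shown here, three built on one shared core have been tested in a functional assay on HEK293 cells for agonist activity at Free fatty acid receptor 1 (Homo sapiens), read by fluorescence and calcium flux; on this read-out lower numbers stand for an effect already at smaller amounts and higher numbers for an effect only at larger amounts of compound. Compound 1 `CC#CC(CC(=O)O)c1ccc(OCc2ccc(C(=O)N3CCN(c4ccccc4)CC3)s2)cc1` carries a phenyl on an amine nitrogen in a ring and gives 72 nM. Compound 3 `CC#CC(CC(=O)O)c1ccc(OCc2ccc(C(=O)N3CCN(c4ccc([N+](=O)[O-])cc4)CC3)s2)cc1` carries a 4-nitrophenyl at the same place and gives 231 nM, which is a 3.2-fold higher number from compound 1 to compound 3 (0.51 log units; beyond the scatter). Compound 2 `CC#CC(CC(=O)O)c1ccc(OCc2ccc(C(=O)N3CCN(C)CC3)s2)cc1` carries only a methyl there, and in this assay compound 2 yields no number, only the limit > 5000 nM. Compound 2 therefore stands at the weak end of the measured set, at the edge of what the assay reports (the limit of > 5000 nM in this assay, at which 1 of the 3 values shown sits).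

Compound 4 `CC#CC(CC(=O)O)c1ccc(OCc2ccc(C(=O)N3CCN(c4ccccc4F)CC3)s2)cc1` is the same core with 2-fluorophenyl in place of methyl on an amine nitrogen in a ring. Within the data shown here, two measured steps bear on this change. In the reverse direction there is an at least 69-fold higher number from compound 1 to compound 2 (1.84 log units; beyond the scatter), and in the same direction an at least 21-fold lower number from compound 2 to compound 3 (1.33 log units; beyond the scatter). Both show that an aromatic ring on that nitrogen instead of a methyl goes together with a much lower number in this assay. A large downward step is therefore expected, meaning an at least 50-fold lower number from compound 2 to compound 4 (1.69 log units; beyond the scatter). Of the two aromatic rings measured, 2-fluorophenyl resembles the phenyl of compound 1, which gives 72 nM, more than the 4-nitrophenyl of compound 3. For compound 4 the value is estimated at 100 nM, within a range from 30 nM to 400 nM.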

Compound 4, half-maximal effective concentration: 113 nM
The estimate for compound 4 lay 1.1-fold (0.05 log units) below the measured number; the range from low to high includes it.
By their numbers in this assay, from the lowest: compounds 1 and 4 (each within the scatter of the next); then compound 3. At a limit, above all of these: compound 2.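

Compound 2 still has no number, only a limit of the assay: the limit of > 5000 nM in this assay, at which 1 of the 4 values shown sits. Against that limit, 2-fluorophenyl on the ring nitrogen gives an at least 44-fold lower number from compound 2 to compound 4 (1.64 log units; beyond the scatter) in this assay, so all three aromatic rings shown on this nitrogen, not just the two known before, go with a much lower number than methyl. The new compound also shows that a group added to the phenyl ring does not always move the number, since fluoro in place of hydrogen gives a 1.6-fold higher number from compound 1 to compound 4 (0.20 log units; within the scatter), whereas the 4-nitrophenyl of compound 3 stays apart from the 2-fluorophenyl, with a 2.0-fold lower number from compound 3 to compound 4 (0.31 log units; beyond the scatter).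

The compounds shown leave open whether the kind of group on the phenyl ring or its place on that ring matters more, as fluoro and nitro differ in both, and a 4-fluorophenyl or a 2-nitrophenyl would separate the two. Going by these compounds, it is also open whether the ring must sit directly on the nitrogen, or whether a benzyl or a non-aromatic cyclohexyl would also go with a low number.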